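Anilino to Hexyloxy on a Sulfamoyl Carbamate Core

A few compounds are considered here, and "the series" means these few. Any claim that something is new, unique, unknown or untested is made for them only; others in the source may bear on it.

Measured compounds:
compound 1 `CCCCCCNS(=O)(=O)NC(=O)Oc1c(C(C)(C)C)cc(C)cc1C(C)(C)C`: 19400 nM
compound 2 `Cc1cc(C(C)(C)C)c(OC(=O)NS(=O)(=O)Nc2ccccc2)c(C(C)(C)C)c1`: 23400 nM

Both numbers come from an assay on liver for inhibition of sterol O-acyltransferase 1 (Rattus norvegicus), using microsomes; on this read-out higher numbers stand for weaker inhibition and lower numbers for stronger inhibition. Compound 2 and compound 1 lie within the scatter of each other: the step of a 1.2-fold higher number from compound 1 to compound 2 (0.08 log units; within the scatter) is too small to place compound 2 above or below compound 1. Compound 3 `CCCCCCOS(=O)(=O)NC(=O)Oc1c(C(C)(C)C)cc(C)cc1C(C)(C)C` has not been measured. It differs from compound 2 by hexyloxy in place of anilino on a sulfonyl sulfur. Going by the values given here, the only measured step, a 1.2-fold higher number from compound 1 to compound 2 (0.08 log units; within the scatter), concerns the group on the sulfonamide nitrogen and shows that exchanging hexyl for phenyl there left the number unchanged within the scatter. No measured step exchanges the nitrogen that links that group to the sulfonyl sulfur for oxygen, so the move to hexyloxy has no direct precedent among these compounds. With both measured compounds sitting close together in this assay, compound 3 is expected to stay near them, the expected step being a 1.2-fold lower number from compound 2 to compound 3 (0.07 log units; within the scatter) with no clear direction. The estimate for compound 3 in this assay is 20000 nM, expected to fall between 7000 nM and 60000 nM.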

Compound 3, half-maximal inhibitory concentration: 95000 nM
Beside the measured number, compound 3's estimate is 4.8-fold (0.68 log units) below it, outside the stated range (above it).
By their numbers in this assay, from the lowest: compounds 1 and 2 (each within the scatter of the next); then compound 3.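

In this assay, the atom that links the chain to the sulfonyl sulfur matters, even though swapping hexyl for phenyl on the nitrogen produced no step beyond the scatter. With the chain held constant, hexyloxy in place of hexylamino gives a 4.9-fold higher number from compound 1 to compound 3 (0.69 log units; beyond the scatter) and so weakens inhibition modestly, and hexyloxy in place of anilino gives a 4.1-fold higher number from compound 2 to compound 3 (0.61 log units; beyond the scatter) in the same direction. Nothing available explains why the oxygen-linked compound is weaker.

The compounds shown leave open whether this loss belongs to the oxygen link in general, since phenoxy on the sulfonyl sulfur would test it against anilino without changing the ring. They also leave open how a shorter chain such as butyloxy, or a tertiary amine carrying two alkyl groups, would compare.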